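The source may report more compounds than this note shows. Statements on the series, on what has been measured and on what is new or still open speak of the compounds shown alone.

Compound 1 `C[C@H]1[C@H](NCc2cncs2)C[C@H]2C[C@@H]1C2(C)C` was examined in an ADME assay on MDCK cells (Canis lupus familiaris) for cytotoxicity, read by microscopy, with a stated time of 48 h; on this read-out lower numbers stand for higher toxicity in this test and higher numbers for lower toxicity in this test. In this assay compound 1 gives only a limit, > 100000 nM, and not a number, which is the limit of > 100000 nM in this assay, at which 1 of the 2 values shown sits; where compound 1 stands on the scale is therefore known only up to that boundary. Compound 2 `CCc1csc(CN[C@@H]2C[C@H]3C[C@@H]([C@H]2C)C3(C)C)c1` gives 25000 nM in this assay. Among the measured compounds shown here, no step between these two measured compounds is recorded, and their two values stand side by side without further comparison.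

Compound 3 `C[C@H]1[C@H](NCc2cnccn2)C[C@H]2C[C@@H]1C2(C)C` remains to be measured. It differs from compound 1 by pyrazin-2-yl in place of 1,3-thiazol-5-yl on a saturated chain carbon bound to an amine nitrogen. For the measured compounds named here, with no measured step to lean on, the expected step of a number no higher from compound 1 to compound 3 (the limit leaves the size open) is taken to be none beyond the scatter. Compound 3 is accordingly estimated at 100000 nM, with a range from 30000 nM to 300000 nM, and it is expected that this assay may again report only a limit for compound 3.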

Compound 3, minimum cytotoxic concentration: > 100000 nM
Compound 3 ended at the assay's limit; the forecaster's own chance of this, stated with the estimate: 60%; the middle value sits exactly at the limit.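

In this assay, among the compounds shown here, no step from compound 1 to compound 3 can be read, because both compounds end at a limit and not at a number: the limit of > 100000 nM in this assay, at which 2 of the 3 values shown sit. The compounds shown leave open whether pyrazin-2-yl in place of 1,3-thiazol-5-yl shifts the minimum cytotoxic concentration at all.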